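The source may hold more compounds than are shown below. What is called first, only, known or untested is meant among the compounds shown, and "the series" means these compounds.

Of the compounds shown here, two have numbers so far in a functional assay on MCF7 cells (Homo sapiens) for inhibition, read by MTT assay (on this read-out lower numbers stand for stronger inhibition and higher numbers for weaker inhibition), and they sit far apart. Compound 1 (`O=C(CCCCCCC(=O)Nc1nnc(-c2ccco2)s1)NO`) gives 880 nM as the higher of the two numbers, which means the weaker inhibition. Compound 2 (`COc1ccc(-c2ocnc2-c2cc(Br)c(OC)c(OC)c2)cc1OCCCC(=O)NO`), a structure of quite a different kind, gives 18 nM and the gap between the two lies beyond the usual scatter of repeat measurements.

Compound 3 (`O=C(CCCCCCC(=O)Nc1nnc(-c2ccc(Br)o2)s1)NO`) keeps the core of compound 1 and alters it in one place (bromo in place of hydrogen on an aromatic carbon), with bromo in place of hydrogen on an aromatic carbon, next to the ring oxygen, so that furan-2-yl turns into 5-bromofuran-2-yl. For the measured compounds named here, no two measured compounds differ in just one place, so the data give no direct guide to the size of such a step. A single swap like this on an unchanged core is usually modest, so in this assay only a small gain in inhibition is expected, possibly none beyond the scatter. The expected size of the change is a 1.5-fold lower number from compound 1 to compound 3 (0.17 log units; within the scatter) on this estimate. Compound 3 is estimated at 600 nM with a likely range of 200 nM to 1600 nM for the coming measurement.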

Compound 3, half-maximal inhibitory concentration: 880 nM
Compound 3: the middle estimate sits 1.5-fold (0.17 log units) below what was measured; low and high end bracket the measured number.
By their numbers in this assay, from the lowest: compound 2; then compounds 1 and 3 (each within the scatter of the next).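

In this assay, putting bromo on the aromatic carbon next to the ring oxygen, which turns furan-2-yl into 5-bromofuran-2-yl, gives no change at the digits printed from compound 1 to compound 3 (within the scatter) and so leaves the inhibition as it was. For the compounds shown here, this is the first pair here that differs in one place, and so the first direct reading of a single change: this position takes on one added heavy atom, a bromine, with no shift that stands out from the scatter of repeat measurements. No separate measurement bears on this step, so the data offer no explanation for the unchanged number.

A single group at a single position cannot show whether this carbon is indifferent to substitution in general, so a methyl, an amine or a carboxylic acid in the same place could still give a different number. The compounds shown also leave open how inhibition responds to changes elsewhere on the core of compound 1, such as a longer chain in place of the present one.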